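This account rests on a few compounds, and the source may have more. Where it says the series, first, only, none or still open, it means among the compounds named here.

Compound 1 `Cc1cc(N2CC[C@@H](C)[C@@H](N(C)c3ncnc4[nH]ccc34)C2)n2nc(SCc3nc4ccccc4[nH]3)nc2n1` gives 21200 nM in a functional assay on MGC-803 cells (Homo sapiens) for inhibition, read by MTT assay, with a stated time of 72 h; a higher number here means a weaker inhibitor, a lower number a stronger inhibitor.
Compound 2 `Cc1cc(N2CC[C@@H](C)[C@@H](N(C)c3ncnc4[nH]ccc34)C2)n2nc(SCc3csc4ccc(Cl)cc34)nc2n1` is reported in this assay only as a limit, > 100000 nM.

Compound 1 holds the only number shown in this assay; the other value is a limit. Compound 3 `Cc1cc(N2CC[C@@H](C)[C@@H](N(C)c3ncnc4[nH]ccc34)C2)n2nc(SCc3cc(Cl)ccc3Cl)nc2n1` differs from compound 1 by 2,5-dichlorophenyl in place of 1H-benzimidazol-2-yl on a saturated chain carbon bound to a sulfur. Among the compounds with values here, the one measured step that bears on this change, an at least 4.7-fold higher number from compound 1 to compound 2 (0.67 log units; beyond the scatter), swapped the same group for another ring at the same place and ran into the limit (the limit of > 100000 nM in this assay, at which 1 of the 2 values shown sits). The step from compound 1 to compound 3 is therefore expected to weaken inhibition, a 3.8-fold higher number from compound 1 to compound 3 (0.58 log units; beyond the scatter). Compound 3 is estimated at 80000 nM, with a range from 25000 nM to 250000 nM.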

Compound 3, half-maximal inhibitory concentration: 9850 nM
Compound 3: middle estimate off by 8.1-fold (0.91 log units), on the high side; measured number below the stated range.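

In this assay, the 1H-benzimidazol-2-yl group can be replaced at this position without loss, and 2,5-dichlorophenyl gives a 2.2-fold lower number from compound 1 to compound 3 (0.33 log units; beyond the scatter), so the hydrogen-bond donor that leaves is not needed for inhibition here. The replacement ring matters strongly, since the two replacements are separated by an at least 10-fold lower number from compound 2 to compound 3 (1.00 log units; beyond the scatter). Compound 2 enters that step only as a limit: the limit of > 100000 nM in this assay, at which 1 of the 3 values shown sits.

From the compounds shown here alone, it remains open whether the gain depends on both chlorines or on the benzene ring itself. An unsubstituted benzyl, a single chlorine or an amine on the ring could separate these readings.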